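The source may report more compounds than this note shows. Statements on the series, on what has been measured and on what is new or still open speak of the compounds shown alone.

Measured so far:
compound 1 `CNC(=O)c1c(C)oc2nc(N3CCCC3)ccc12` — "not determined" (no result reported)
compound 2 `CC(C)c1oc2nc(N3CCCC3)ccc2c1C(=O)O` — "not determined" (no result reported)
compound 3 `CCOC(=O)c1c(C)oc2nc(N3CCCC3)ccc12` — 196000 nM

The three compounds share one core and differ in the groups on the five-membered ring. For the measured compounds named here, for compound 1 and compound 2 no result was reported, so compound 3 carries the only number of the set. Going by the values given here, in an ADME assay on J774.A1 cells (Mus musculus) for cytotoxicity, read by fluorescence and resazurin assay, with a stated time of 24 h (a lower number here means a stronger inhibitor, a higher number a weaker inhibitor), compound 3 gives 196000 nM, a weak effect at a high concentration, and with no second number alongside it there is no step between measured compounds to set a scale.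

Compound 4 `CCOC(=O)c1c(C(C)C)oc2nc(N3CCCC3)ccc12` is the next entry, not yet measured. It differs from compound 3 in one place: isopropyl in place of methyl on an aromatic carbon. The ethoxycarbonyl group and the rest of the core are kept. Among the compounds with values here, with no measured pair that shows what such an exchange does, the expected step from compound 3 to compound 4, a 1.3-fold lower number from compound 3 to compound 4 (0.12 log units; within the scatter), is small and within the usual scatter, with no clear direction. For compound 4 the estimate in this assay is therefore 150000 nM, expected to fall between 60000 nM and 400000 nM.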

Compound 4, half-maximal inhibitory concentration: > 330000 nM
Compound 4 gave a limit, no number; the forecaster's own chance of this, stated with the estimate: 30%; middle value at least 2.2-fold (0.34 log units) from the limit.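

In this assay compound 4 gives > 330000 nM, which is a limit of the assay and not a number. Going by these compounds, the exchange of methyl for isopropyl on the aromatic carbon next to the ring oxygen gives an at least 1.6-fold higher number from compound 3 to compound 4 (0.22 log units; that floor lies within the scatter), so this first step at the position has a direction but only a floor for its size, and the true size remains unknown. The read-out for this position has now reached the edge of its range: the limit of > 330000 nM in this assay, at which 1 of the 4 values shown sits.

With one number and one limit, the series gives no scale for changes at this position. Open, on these data alone, is what an amine or a longer chain on this carbon would do to the number, and whether any such group would give a value clear of the limit.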